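An Amide Substituent Swap in a Cell-Based Inhibition Assay

This account rests on a few compounds, and the source may have more. Where it says the series, first, only, none or still open, it means among the compounds named here.

Compound 1 `COc1ccc2c(=O)c(/C=C/C(=O)NCc3cccc(F)c3)coc2c1` reaches only the limit > 200000 nM in a functional assay on L02 cells (Homo sapiens) for inhibition, read by MTT assay, with a stated time of 48 h; a lower number here means a stronger inhibitor, a higher number a weaker inhibitor.
Compound 2 `Cc1ccccc1NC(=O)/C=C/c1coc2cc(O)ccc2c1=O` likewise reaches only the limit > 200000 nM in this assay.
Compound 3 `O=C(/C=C/c1coc2cc(O)ccc2c1=O)Nc1ccccc1` also reaches only the limit > 200000 nM in this assay.

Within the data shown here, all three measured values are limits of the assay rather than numbers, so compound 1 stands at the same limit as the others, and the single one-point step, a step that the two limits leave unreadable from compound 2 to compound 3, cannot be sized. Compound 4 `CCOc1ccc(NC(=O)/C=C/c2coc3cc(OC)ccc3c2=O)cc1` differs from compound 1 by 4-ethoxyphenyl in place of 3-fluorobenzyl on an amide-type nitrogen. Among the measured compounds shown here, no measured step covers this change; the only evidence on the series is the limit of > 200000 nM in this assay, at which 3 of the 3 values shown sit. The step that the limit leaves unreadable from compound 1 to compound 4 is therefore expected to show no change beyond the scatter, with the assay most likely reporting a limit again. Compound 4 is estimated at 300000 nM, between 100000 nM and 1000000 nM.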

Compound 4, half-maximal inhibitory concentration: > 200000 nM
Compound 4 ended at the assay's limit; the forecaster's own chance of this, stated with the estimate: 90%; the middle value lies beyond the limit too.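

Compound 1 and compound 4 both give a limit of the assay rather than a number, so the step between them cannot be read: the limit of > 200000 nM in this assay, at which 4 of the 4 values shown sit.

The compounds shown leave open which group on the amide-type nitrogen, if any, would give a measurable value in this assay.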